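Bromo on the phenylsulfonyl group of compound 2

A few compounds are considered here, and "the series" means these few. Any claim that something is new, unique, unknown or untested is made for them only; others in the source may bear on it.

Within the data shown here, in a functional assay on HepG2 cells (Homo sapiens) for antiproliferative activity, read by MTT assay, with a stated time of 24 h (a higher number here means a weaker inhibitor, a lower number a stronger inhibitor), compound 1 `Cc1ccc(-c2nn(-c3ccccc3)cc2-c2nc3ccccc3n2S(=O)(=O)c2ccccc2)cc1` gives 960 nM and compound 2 `O=S(=O)(c1ccccc1)n1c(-c2cn(-c3ccccc3)nc2-c2ccc(F)cc2)nc2ccccc21` gives 720 nM as the only two numbers so far. Among the measured compounds shown here, the single measured step is a 1.3-fold lower number from compound 1 to compound 2 (0.12 log units; within the scatter) and leaves compound 2 level with compound 1. Compound 3 `O=S(=O)(c1ccc(Br)cc1)n1c(-c2cn(-c3ccccc3)nc2-c2ccc(F)cc2)nc2ccccc21` differs from compound 2 by bromo in place of hydrogen on an aromatic carbon and so turns phenylsulfonyl to (4-bromophenyl)sulfonyl. For the measured compounds named here, no measured step changes this group, so the only guide is a small step elsewhere on the molecule. The expected change in this assay is a 1.1-fold lower number from compound 2 to compound 3 (0.04 log units; within the scatter) with no firm direction. Compound 3 is expected at 650 nM (estimated range 250 nM to 1700 nM).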

Compound 3, half-maximal inhibitory concentration: 2550 nM
For compound 3 the middle estimate is 3.9-fold (0.59 log units) below the measured one; measured number above the stated range.
By their numbers in this assay, from the lowest: compounds 2 and 1 (each within the scatter of the next); then compound 3.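

Adding bromo to the phenylsulfonyl group gives a 3.5-fold higher number from compound 2 to compound 3 (0.55 log units; beyond the scatter) in this assay and so makes the compound a weaker inhibitor. This is the first step shown that lies beyond the scatter, so this ring carbon, unlike the simple change elsewhere on the molecule, does respond to a single added heavy atom. Nothing available explains this loss.

From the compounds shown here alone, whether the loss is specific to bromo or would follow any group here remains open. Fluoro, methoxy or an amine on this same carbon would help to separate those possibilities.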